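Adding bromine to compound 3: an expected cytotoxicity value

The compounds below may be only part of what the source reports. "The series", "measured", "known", "first", "only" and "open" are said of these compounds alone.

Measured compounds:
compound 1 `CN(C)c1nc(NNC(=O)Nc2cc(Cl)nc(Cl)c2)nc2c1ccn2C` gives 58500 nM
compound 2 `Cn1ccc2c(-c3ccccc3)nc(NNC(=O)Nc3cc(Cl)nc(Cl)c3)nc21` gives 683000 nM
compound 3 `O=C(Nc1cc(Cl)nc(Cl)c1)Nc1cc2ccccn2n1` gives 10200 nM

In an ADME assay on NCM460 cells (Homo sapiens) for cytotoxicity, read by MTT assay, with a stated time of 72 h, in the presence of a further agent that is not named here (on this read-out higher numbers stand for an effect only at larger amounts of compound and lower numbers for an effect already at smaller amounts), compound 3 stands at the lowest of the three numbers, so its effect appears at smaller amounts than that of compound 1 or compound 2. Compound 4 `O=C(Nc1cc(Cl)nc(Cl)c1)Nc1cc2ccc(Br)cn2n1` is not yet measured. It differs from compound 3 in one place: bromo in place of hydrogen on an aromatic carbon. The only measured step among these compounds is a 12-fold higher number from compound 1 to compound 2 (1.07 log units; beyond the scatter), which concerns a different change on a different core and gives no guide to a bromine replacing a hydrogen. Nothing in the measurements speaks directly to the step from compound 3 to compound 4. Among the compounds with values here, with no step bearing on it, the expectation in this assay for compound 4 is a number close to that of compound 3, with no change beyond the scatter, as expressed by a 1.0-fold lower number from compound 3 to compound 4 (0.01 log units; within the scatter). Compound 4 is therefore estimated at 10000 nM, within a range from 3500 nM to 30000 nM.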

Compound 4, half-maximal effective concentration: 8940 nM
The estimate for compound 4 lay 1.1-fold (0.05 log units) above the measured number; the range from low to high includes it.
By their numbers in this assay, from the lowest: compounds 4 and 3 (each within the scatter of the next); then compound 1; then compound 2.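

In this assay, bromo in place of hydrogen on this aromatic carbon, two atoms from the ring nitrogen, gives a 1.1-fold lower number from compound 3 to compound 4 (0.06 log units; within the scatter) and so moves the number by no more than repeated measurements would. Within the data shown here, the earlier compounds could not show this, since their one step, a 12-fold higher number from compound 1 to compound 2 (1.07 log units; beyond the scatter) on another core, involved a different change at a different place. The measurements offer no explanation for this outcome.

A single bromine atom says little about how other groups would behave at this position, such as an amine, a carboxylic acid or a longer chain. On these data alone, it also remains open whether bromo would give a similarly small step on another aromatic carbon of the same ring.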